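This account rests on a few compounds, and the source may have more. Where it says the series, first, only, none or still open, it means among the compounds named here.

Measured in an ADME assay on the whole organism (strain Sprague-Dawley) for pharmacokinetics, with Rattus norvegicus as the target, read by LC-MS, at a dose of 5 mg/kg by the intravenous route; on this read-out higher numbers stand for higher exposure at the dose given and lower numbers for lower exposure:
- compound 1 `C=CC(=O)N1CC[C@H](N2C(=O)N(Cc3ccccc3)Cc3cnc(Nc4ccc(N5CCN(C)CC5)cc4OC)nc32)C1`: 1350 nM
- compound 2 `C=CC(=O)N1CC[C@H](N2C(=O)N(c3ccccc3)Cc3cnc(Nc4cccc(N5CCN(C)CC5)c4)nc32)C1`: 3380 nM
- compound 3 `C=CC(=O)N1CC[C@H](N2C(=O)N(c3ccccc3)Cc3cnc(Nc4ccc(N5CCN(C)CC5)c(C)c4)nc32)C1`: 7190 nM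

Compound 2 stands second highest of the three numbers; compound 3 sits above it beyond the scatter, and compound 1 sits further below it, also beyond the scatter. Compound 4 `C=CC(=O)N1CC[C@H](N2C(=O)N(c3ccccc3)Cc3cnc(Nc4ccccc4)nc32)C1` is not yet measured in this assay. It differs from compound 2 in one place: hydrogen in place of 4-methylpiperazin-1-yl on an aromatic carbon. Among the compounds with values here, no measured pair shows this change, so no step of this kind is known here. A modest step upward is expected, a 1.5-fold higher number from compound 2 to compound 4 (0.17 log units; within the scatter), of a size that may fall within the scatter. Compound 4 is therefore estimated at 5000 nM, with a range from 2000 nM to 12000 nM.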

Compound 4, maximal plasma concentration: 14900 nM
Estimate against measurement, compound 4: 3.0-fold (0.47 log units) below, outside the stated range (above it).
By their numbers in this assay, from the lowest: compound 1; then compound 2; then compound 3; then compound 4.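

In this assay, hydrogen in place of 4-methylpiperazin-1-yl on this aromatic carbon gives a 4.4-fold higher number from compound 2 to compound 4 (0.64 log units; beyond the scatter). At this place, then, the 4-methylpiperazin-1-yl group is not required for a high maximal plasma concentration, and the unsubstituted ring gives the higher number, though this rests on a single pair. Nothing measured here bears on the reason for the rise.

Still open, on these data alone, is whether a smaller group on this carbon, such as a dimethylamino group or a methoxy group, would stay near compound 4 or fall back towards compound 2. Also open, as far as these compounds go, is whether a morpholine ring would behave like the 4-methylpiperazin-1-yl group.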